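A few compounds are considered here, and "the series" means these few. Any claim that something is new, unique, unknown or untested is made for them only; others in the source may bear on it.

Among the measured compounds shown here, compound 2 `CN(C)CCN1CCN(c2nc(-c3ccccn3)nc3c2CN(Cc2ccccc2)CC3)CC1` gives 1500 nM in an assay on FRT cells with Cystic fibrosis transmembrane conductance regulator variant F508del (Homo sapiens) as the target, read by fluorescence, with a stated time of 25 min (on this read-out lower numbers stand for an effect already at smaller amounts and higher numbers for an effect only at larger amounts of compound), the higher of the two numbers measured so far; its neighbour compound 1 `NC(=O)C1CCN(c2nc(-c3ccccn3)nc3c2CN(Cc2ccccc2)CC3)CC1` gives 1400 nM there. For the measured compounds named here, the only measured step, a 1.1-fold higher number from compound 1 to compound 2 (0.03 log units; within the scatter), changes a different part of the core and says nothing direct about the group on the ring amine. Compound 3 `CN(C)CCN1CCN(c2nc(-c3ccccn3)nc3c2CN(Cc2ccsc2)CC3)CC1` carries thiophen-3-yl in place of phenyl on a saturated chain carbon bound to an amine nitrogen in a ring. Going by the values given here, with no comparable step to draw on, the expected step of no change at the digits printed from compound 2 to compound 3 (within the scatter) in this assay is none beyond the scatter. Compound 3 is therefore estimated at 1500 nM in this assay, with a range from 700 nM to 3200 nM.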

Compound 3, half-maximal effective concentration: 200 nM
Compound 3: the middle estimate sits 7.5-fold (0.88 log units) above what was measured; measured number below the stated range.
By their numbers in this assay, from the lowest: compound 3; then compounds 1 and 2 (each within the scatter of the next).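

In this assay, thiophen-3-yl in place of phenyl on a saturated chain carbon bound to an amine nitrogen in a ring gives a 7.5-fold lower number from compound 2 to compound 3 (0.88 log units; beyond the scatter) and so shows that the number responds to the aromatic ring at this position. This is the first step beyond the scatter among the compounds shown. No measurement at hand accounts for this step. On these data alone, whether thiophen-2-yl or furan-3-yl would give a similar step stays open. So does whether the step would carry over with the 4-carbamoylpiperidin-1-yl group of compound 1 in place of the 4-(2-(dimethylamino)ethyl)piperazin-1-yl group.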